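Swapping the terminal aryl ring: lipophilicity of compound 4

The compounds below may be only part of what the source reports. "The series", "measured", "known", "first", "only" and "open" are said of these compounds alone.

Measured compounds:
compound 1, `CC[C@@H](Nc1c(C#N)c(-c2ccc(-c3cccc(C)c3F)cc2)nc2cnccc12)C(N)=O`, 3
compound 2, `CCOc1ccccc1-c1ccc(-c2nc3cnccc3c(N)c2C#N)cc1`, 3
compound 3, `CCOc1ccccc1-c1ccc(-c2nc3cnccc3c(NC(CC)CNS(=O)(=O)C3CC3)c2C#N)cc1`, 3.6

Of the compounds shown here, three built on a shared core have been measured in a physicochemical assay for lipophilicity, read by HPLC, at pH 7.5; on this read-out higher numbers stand for higher lipophilicity and lower numbers for lower lipophilicity. Compound 1 sits level with compound 2 at the digits recorded, and together they give the lowest two numbers of the three; compound 3 stands furthest from compound 1, a number higher beyond the scatter. Among the measured compounds shown here, the one step within a single change, a number 0.60 log units higher from compound 2 to compound 3 (beyond the scatter), concerns the substituent on the ring nitrogen, not the terminal aryl ring.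

The next compound, compound 4, `CC[C@@H](Nc1c(C#N)c(-c2ccc(-c3ccccc3C(C)C)cc2)nc2cnccc12)C(N)=O`, differs from compound 1 in exactly one place: 2-isopropylphenyl in place of 2-fluoro-3-methylphenyl on an aromatic carbon. For the measured compounds named here, no measured step bears directly on an exchange at this position. The recorded step from compound 2 to compound 3 touches a different site and gives no guide here. For compound 4 in this assay a modest rise is expected, with the step of a number 0.40 log units higher from compound 1 to compound 4 (beyond the scatter) estimated for this exchange. The estimate for compound 4 is therefore 3.4, within a range of 3 to 3.8.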

Compound 4, distribution coefficient: 3.5
Estimate against measurement, compound 4: 0.10 log units below; the measured number falls inside the stated range.
By their numbers in this assay, from the lowest: compounds 1 and 2 (each within the scatter of the next); then compounds 4 and 3 (each within the scatter of the next).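

In this assay, among the compounds shown here, the terminal aryl ring proves to be a position that responds: 2-isopropylphenyl in place of 2-fluoro-3-methylphenyl gives a number 0.50 log units higher from compound 1 to compound 4 (beyond the scatter) and is the first step read at this site, as the earlier step concerned a different one. The exchange keeps a six-membered aromatic ring of carbon only, with no hydrogen-bond donors or acceptors and no net charge on either group, yet the number still moves beyond the scatter. Nothing on hand gives a cause for this step.

For the compounds shown here, the single exchange removes the fluorine and alters the alkyl substitution together, so what each part contributes stays open. Also open, going by these compounds, is how an amine or a carboxylic acid on the terminal ring would stand in this assay against compound 1.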